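The compounds below may be only part of what the source reports. "The series", "measured", "known", "first", "only" and "open" are said of these compounds alone.

Measured compounds:
- compound 1 `ClCc1ccc(Cn2cnc3c(Cl)ncnc32)cc1`: 20900 nM in a functional assay on SK-MEL-5 cells (Homo sapiens) for cytotoxicity, read by sulforhodamine B assay, with a stated time of 48 h; on this read-out higher numbers stand for weaker inhibition of growth and lower numbers for stronger inhibition of growth
- compound 2 `ClCc1ccccc1Cn1cnc2c(Cl)nc(Cl)nc21`: 1540 nM in this assay

Compound 2 holds the lower of the two numbers; compound 1 gives the higher one, and the gap between the two values lies beyond the usual scatter. Going by the values given here, no step between compounds that differ in one place is available, so nothing is known from this series about what a single change on the shared core does.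

Compound 3 `ClCc1ccccc1Cn1cnc2c(Cl)ncnc21` is the next member to be measured in this assay. It differs from compound 2 by hydrogen in place of chloro on an aromatic carbon. Compound 3 thus carries the same core as compound 1 while keeping the benzyl arrangement of compound 2.

Among the compounds with values here, with no measured step for removing a chloro from the core, the direction is taken from the fact that the compound with the higher value, compound 1, is the one carrying a single chloro on the core. The expected step from compound 2 to compound 3 is therefore a 3.9-fold higher number from compound 2 to compound 3 (0.59 log units; beyond the scatter), toward weaker growth inhibition, of a size that goes beyond the scatter. Compound 3 is estimated at 6000 nM, with a range from 2000 nM to 25000 nM.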

Compound 3, concentration for total growth inhibition: 2880 nM
Compound 3: middle estimate off by 2.1-fold (0.32 log units), on the high side, within the range that was stated.
By their numbers in this assay, from the lowest: compounds 2 and 3 (each within the scatter of the next); then compound 1.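

In this assay, a 1.9-fold higher number from compound 2 to compound 3 (0.27 log units; within the scatter) gives the series its first measured step between compounds that differ in one place, and that step lies within the scatter. At this position, on an aromatic carbon between two ring nitrogen atoms, the read-out therefore does not separate chloro from hydrogen, so the growth inhibition seen with compound 2 does not depend on this chloro, as compound 3 stays within the scatter of it without the group. Nothing at hand bears on the reason for this result.

Still open is whether a larger or differently bonded group at this same position, such as an amine or a methoxy group, would move the number beyond the scatter, since hydrogen and chloro are the only two substituents shown there. Also open is what lies behind the gap between compound 1 at 20900 nM and compound 3 at 2880 nM: the two share a core but differ in the benzyl arrangement, and no single step connects that arrangement to the values.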